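A few compounds are considered here, and "the series" means these few. Any claim that something is new, unique, unknown or untested is made for them only; others in the source may bear on it.

Within the data shown here, in a functional assay on HEL cells (Homo sapiens) for inhibition (on this read-out higher numbers stand for weaker inhibition and lower numbers for stronger inhibition), compound 3 (`CC(C)c1cc(-c2n[nH]c(=O)n2-c2ccc(C(=O)NCCCCCC(=O)NO)cc2)c(O)cc1O`) gives 4600 nM and stands level with compound 1 (`CC(C)c1cc(-c2n[nH]c(=O)n2-c2cccc(C(=O)NCCCCCCC(=O)NO)c2)c(O)cc1O`) at 4600 nM and compound 2 (`CC(C)c1cc(-c2n[nH]c(=O)n2-c2ccc(C(=O)NCCCCCCCC(=O)NO)cc2)c(O)cc1O`) at 4600 nM on the numbers so far. Compound 4 (`CC(C)c1cc(-c2n[nH]c(=O)n2-c2ccc(C(=O)NCCCC(=O)NO)cc2)c(O)cc1O`) has not yet been measured. Its structural change is hydroxycarbamoyl in place of 2-(hydroxycarbamoyl)ethyl on a saturated chain carbon, three bonds along the chain from an amide-type nitrogen and this falls on a saturated chain carbon, three bonds along the chain from an amide-type nitrogen. Among the measured compounds shown here, the only measured guide is no change at the digits printed from compound 2 to compound 3 (within the scatter) and that same swap, made five bonds along the chain, stayed within the scatter. A single step is thin evidence for a still shorter chain, so the range is kept wide. The expected step is a 1.1-fold higher number from compound 3 to compound 4 (0.04 log units; within the scatter) with no shift beyond the scatter anticipated in this assay for this change. Compound 4 is estimated at 5000 nM with an expected range from 2300 nM to 12000 nM in this measurement.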

Compound 4, half-maximal inhibitory concentration: 4600 nM
Estimate against measurement, compound 4: 1.1-fold (0.04 log units) above; the range from low to high includes it.
By their numbers in this assay, from the lowest: compounds 1, 2, 3 and 4 (each within the scatter of the next).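

In this assay, the swap of hydroxycarbamoyl for 2-(hydroxycarbamoyl)ethyl, now three bonds along the chain from an amide-type nitrogen, shows no change at the digits printed from compound 3 to compound 4 (within the scatter), so what was seen five bonds along also holds at this second place. The larger swap at the same place, hydroxycarbamoyl for 4-(hydroxycarbamoyl)butyl, shows no change at the digits printed from compound 2 to compound 4 (within the scatter). Nothing here explains why these chain differences leave the number flat. Still open, from the compounds shown here alone, is whether a carboxylic acid in place of the hydroxycarbamoyl, or a longer chain than that of compound 2, would move the number beyond the scatter.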